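This account rests on a few compounds, and the source may have more. Where it says the series, first, only, none or still open, it means among the compounds named here.

Measured so far:

Compound 1, `O=C(O)CCCCOc1ccc2c(=O)c(-c3ccc(O)cc3)coc2c1`, gives 100 nM in an assay (Cricetulus griseus) for inhibition of aldehyde dehydrogenase, mitochondrial (Homo sapiens); on this read-out higher numbers stand for weaker inhibition and lower numbers for stronger inhibition.
Compound 2, `O=C(O)COc1ccc2c(=O)c(-c3ccc(O)cc3)coc2c1`, gives 1200 nM in this assay.
Compound 3, `O=C(O)CCCCCCCCCOc1ccc2c(=O)c(-c3ccc(O)cc3)coc2c1`, gives 50 nM in this assay.

The three compounds share one core and differ only in the acid-bearing chain on the aryl oxygen. Shortening that chain from compound 1 to compound 2, described as carboxy in place of 3-carboxypropyl on a saturated chain carbon bound to an oxygen on an aromatic ring, gave a 12-fold higher number from compound 1 to compound 2 (1.08 log units; beyond the scatter). Lengthening it from compound 1 to compound 3, described as 5-carboxypentyl in place of carboxy on a saturated chain carbon, four bonds along the chain from an oxygen on an aromatic ring, gave a 2.0-fold lower number from compound 1 to compound 3 (0.30 log units; within the scatter), so compound 1 and compound 3 cannot be told apart on this read-out, while compound 2 stands clearly apart from both.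

Compound 4, `O=C(O)CCCCCCOc1ccc2c(=O)c(-c3ccc(O)cc3)coc2c1`, has not yet been measured. It derives from compound 3 by carboxy in place of 3-carboxypropyl on a saturated chain carbon, six bonds along the chain from an oxygen on an aromatic ring. For the measured compounds named here, this is the same kind of change as the one from compound 1 to compound 2, but not the same: there the place was on a saturated chain carbon bound to an oxygen on an aromatic ring, here it is on a saturated chain carbon six bonds along the chain from an oxygen on an aromatic ring. The chain of compound 4 lies between those of compound 1 and compound 3, and the two of them sit within the scatter of each other because a 2.0-fold lower number from compound 1 to compound 3 (0.30 log units; within the scatter). Compound 4 is therefore expected to give a step of a 1.4-fold higher number from compound 3 to compound 4 (0.15 log units; within the scatter), far smaller than the step from compound 1 to compound 2. The estimate for compound 4 in this assay is 70 nM, expected to fall between 30 nM and 160 nM.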

Compound 4, half-maximal inhibitory concentration: 50 nM
Compound 4: middle estimate off by 1.4-fold (0.15 log units), on the high side; low and high end bracket the measured number.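

Cutting the chain of compound 3 gave no change at the digits printed from compound 3 to compound 4 (within the scatter), so in this assay the replacement of 3-carboxypropyl by carboxy, large on the chain of compound 1, does not carry over to the longer chain: the same change on two cores in this assay, a 12-fold higher number (1.08 log units; beyond the scatter) from compound 1 to compound 2 and no change at the digits printed (within the scatter) from compound 3 to compound 4, 12-fold (1.08 log units) apart, beyond the scatter of two such steps

The reverse change, adding the same stretch of chain, does not carry over either, giving a 24-fold lower number from compound 2 to compound 4 (1.38 log units; beyond the scatter) when it starts from the carboxymethyl chain of compound 2: the same change on two cores in this assay, a 2.0-fold lower number (0.30 log units; within the scatter) from compound 1 to compound 3 and a 24-fold lower number (1.38 log units; beyond the scatter) from compound 2 to compound 4, 12-fold (1.08 log units) apart, beyond the scatter of two such steps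

With a 2.0-fold lower number from compound 1 to compound 4 (0.30 log units; within the scatter) as well, compound 1, compound 3 and compound 4 cannot be told apart on this read-out, so among these four compounds the size of the step depends on the chain it starts from, and only compound 2 stands apart, but this does not show a rule for other chains or for any other core.

How a 2-carboxyethyl or 3-carboxypropyl chain on the oxygen on an aromatic ring would read in this assay stays open, so the compounds shown do not fix where the large step arises. Also open, as far as these compounds go, is whether the chain must end in a carboxylic acid at all, or whether an amide, an ester or an amine at the chain end would read the same.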